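This account rests on a few compounds, and the source may have more. Where it says the series, first, only, none or still open, it means among the compounds named here.

Compound 1 `O=C(CCl)N1CCCC(n2nc(-c3ccc(Oc4ccccc4)cc3)cc2CO)C1`: 1100 nM
Compound 2 `C=CC(=O)Nc1ccc(Cn2nc(-c3ccc(Oc4ccccc4)cc3)cc2C(=O)O)cc1`: > 60000 nM

In a functional assay on Maver1 cells (Homo sapiens) for inhibition, read by luminescence and CellTiter-Glo, with a stated time of 72 h (a lower number here means a stronger inhibitor, a higher number a weaker inhibitor), compound 1 gives 1100 nM. Compound 2 gives only a limit of the assay, > 60000 nM, so no number is known for it. It stands at the limit of > 60000 nM in this assay, at which 1 of the 2 values shown sits. Compound 3 `C/C=C/C(=O)Nc1ccc(Cn2nc(-c3ccc(Oc4ccccc4)cc3)cc2C(=O)O)cc1` differs from compound 2 by prop-1-en-1-yl in place of vinyl on a carbonyl carbon. Among the measured compounds shown here, no measured pair shows this change, so its effect is unknown. Because compound 2 stands at the limit of > 60000 nM in this assay, at which 1 of the 2 values shown sits, the step is estimated as a step that the limit leaves unreadable from compound 2 to compound 3, not beyond the scatter in either direction. Compound 3 is therefore expected at about 70000 nM, somewhere between 20000 nM and 200000 nM.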

Compound 3, half-maximal inhibitory concentration: > 60000 nM
Compound 3 gave a limit, no number (the forecaster's own chance of this, stated with the estimate: 85%); the middle value does not contradict the limit.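

Among the compounds shown here, compound 2 and compound 3 both give only a limit of the assay, not a number, so no step between them can be read. As far as these compounds go, whether prop-1-en-1-yl in place of vinyl on a carbonyl carbon changes inhibition at all stays open.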